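Adding an Acetyl Group to the Amino Group of Compound 2

The source may report more compounds than this note shows. Statements on the series, on what has been measured and on what is new or still open speak of the compounds shown alone.

For the measured compounds named here, in an ADME assay on HEK293 cells (Homo sapiens) for cytotoxicity, read by fluorescence and resazurin assay, with a stated time of 24 h (on this read-out higher numbers stand for lower toxicity in this test and lower numbers for higher toxicity in this test), compound 1 `COC(=O)c1ccc(-c2nnc(SC3=CS(=O)(=O)c4ccccc43)o2)cc1` gives 4000 nM and compound 2 `Nc1ccc(-c2nnc(SC3=CS(=O)(=O)c4ccccc43)o2)cc1` gives 4000 nM so compound 2 stands level with compound 1 on the numbers so far. Going by the values given here, the one measured step is no change at the digits printed from compound 1 to compound 2 (within the scatter) for amino in place of methoxycarbonyl on an aromatic carbon. Compound 3 `CC(=O)Nc1ccc(-c2nnc(SC3=CS(=O)(=O)c4ccccc43)o2)cc1` differs from compound 2 by acetyl in place of hydrogen on a nitrogen on an aromatic ring with acetyl in place of hydrogen on a nitrogen on an aromatic ring, so amino becomes acetamido. Among the compounds with values here, no acetyl change has been measured here, which leaves the step between compound 1 and compound 2 as the only guide, and a weak one. No shift beyond the scatter is therefore expected in this assay and the estimated step is no change at the digits printed from compound 2 to compound 3 (within the scatter) with no direction favoured. Compound 3 is estimated at 4000 nM with an expected range from 1700 nM to 10000 nM for the coming measurement.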

Compound 3, half-maximal cytotoxic concentration: 4000 nM
The estimate for compound 3 equals the measured number at the digits printed; the measured number falls inside the stated range.
By their numbers in this assay, from the lowest: compounds 1, 2 and 3 (each within the scatter of the next).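

In this assay, putting acetyl in place of hydrogen on the nitrogen gives no change at the digits printed from compound 2 to compound 3 (within the scatter), and acetamido in place of methoxycarbonyl on the aromatic carbon gives no change at the digits printed from compound 1 to compound 3 (within the scatter). This aromatic carbon has now carried methoxycarbonyl, amino and acetamido, and this read-out cannot tell the three compounds apart, even with the 3 heavy atoms of the acetyl added to the nitrogen. No supporting measurement bears on why these three compounds read alike.

On these data alone, it remains open whether a carboxylic acid on the same aromatic carbon, or a longer chain such as butanoyl on the nitrogen, would read the same. These three compounds also cannot show whether the shared core alone sets this level of cytotoxicity, since all of them contain it.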